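The source may report more compounds than this note shows. Statements on the series, on what has been measured and on what is new or still open speak of the compounds shown alone.

Working notes on the series.

Compound 1, `CNS(=O)(=O)c1ccc(-c2cnc(N)c(-c3ccc(OC)nc3)c2)cc1`, has been measured in a physicochemical assay for solubility, read by nephelometry, measured as kinetic solubility, at pH 2; on this read-out higher numbers stand for higher solubility and lower numbers for lower solubility. In this assay compound 1 gives > 100 ug/mL, which is a limit of the assay and not a number. Compound 2, `COc1ccc(-c2cc(-c3ccc(S(C)(=O)=O)c(F)c3)cnc2N)cn1`, gives in this assay > 100 ug/mL, again a limit rather than a number. Compound 3, `COc1ccc(-c2cc(-c3ccc(S(C)(=O)=O)cc3C(F)(F)F)cnc2N)cn1`, gives in this assay > 100 ug/mL, also a limit. Among the measured compounds shown here, compound 1 therefore stands at the limit of > 100 ug/mL in this assay, at which 3 of the 3 values shown sit, and no step between measured compounds can be sized, since every value reported so far is the same limit and no pair of them differs in a single place.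

Compound 4, `COc1ccc(-c2cc(-c3ccc(C(N)=O)cc3)cnc2N)cn1`, is not yet measured in this assay. Relative to compound 1 the change is carbamoyl in place of methylsulfamoyl on an aromatic carbon. For the measured compounds named here, no measured step gives a size for a change of this kind, and the shared core of compound 1 and compound 4 is otherwise unchanged. The expected step is a number no higher from compound 1 to compound 4 (the limit leaves the size open), that is, none beyond the usual scatter. Compound 4 is accordingly expected to come out at about 100 ug/mL, with a range from 50 ug/mL to 200 ug/mL, most probably reported again as a limit.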

Compound 4, solubility: > 100 ug/mL
Compound 4 ended at the assay's limit; the forecaster's own chance of this, stated with the estimate: 70%; the middle value lies on the limit itself.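

The step between compound 1 and compound 4 in this assay cannot be read, because both compounds stand at the same limit, which is not a number: the limit of > 100 ug/mL in this assay, at which 4 of the 4 values shown sit. The compounds shown leave open how far any of them lies beyond that limit, and so whether carbamoyl in place of methylsulfamoyl on an aromatic carbon shifts the read-out at all.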